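The source may hold more compounds than are shown below. What is called first, only, known or untested is meant among the compounds shown, and "the series" means these compounds.

Measured compounds:
compound 1, `O=C(O)COc1ccc(NCc2cccc(-c3ccccc3F)c2)cc1F`, 36.5 nM in a functional assay on CHO cells for agonist activity at Free fatty acid receptor 1 (Homo sapiens), read by FLIPR and calcium flux; on this read-out lower numbers stand for an effect already at smaller amounts and higher numbers for an effect only at larger amounts of compound
compound 2, `O=C(O)COc1ccc(NCc2cccc(-c3ccccc3Cl)c2)cc1F`, 19.3 nM in this assay
compound 3, `COc1ccccc1-c1cccc(CNc2ccc(OCC(=O)O)c(F)c2)c1`, 536 nM in this assay

Compound 3 gives the highest number of the three. The step of a 15-fold higher number from compound 1 to compound 3 (1.17 log units; beyond the scatter) and the step of a 28-fold higher number from compound 2 to compound 3 (1.44 log units; beyond the scatter) both lie beyond the scatter, so compound 3 acts only at clearly larger amounts than the other two. The step of a 1.9-fold lower number from compound 1 to compound 2 (0.28 log units; within the scatter), by contrast, stays within the scatter.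

Compound 4, `Cc1ccc(-c2cccc(CNc3ccc(OCC(=O)O)c(F)c3)c2)c(Cl)c1`, has not yet been measured. It differs from compound 3 in one place: 2-chloro-4-methylphenyl in place of 2-methoxyphenyl on an aromatic carbon. Among the measured compounds shown here, the steps that bear on this are those in which methoxy entered, a 15-fold higher number from compound 1 to compound 3 (1.17 log units; beyond the scatter) and a 28-fold higher number from compound 2 to compound 3 (1.44 log units; beyond the scatter); removing it and putting chloro in its place runs the second of these backwards. For the measured compounds named here, the methyl that the entering group also carries has no counterpart among the measured compounds, and its effect is unknown. A large drop in the number is therefore expected, back toward the value of compound 2. Compound 4 is expected to give about 25 nM in this assay, most likely between 8 nM and 90 nM. The expected step is a 21-fold lower number from compound 3 to compound 4 (1.33 log units; beyond the scatter).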

Compound 4, half-maximal effective concentration: 22.5 nM
Compound 4: middle estimate off by 1.1-fold (0.05 log units), on the high side, and the stated range covers the measured number.
By their numbers in this assay, from the lowest: compounds 2, 4 and 1 (each within the scatter of the next); then compound 3.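

In this assay, swapping the 2-methoxyphenyl group for the 2-chloro-4-methylphenyl group gives a large change (a 24-fold lower number from compound 3 to compound 4 (1.38 log units; beyond the scatter)), although both groups have 8 heavy atoms, so the count of heavy atoms alone does not separate a high number from a low one at this place. Among the compounds shown here, the methyl, the one part of the new group not covered by the earlier compounds, leaves no readable mark here (a 1.2-fold higher number from compound 2 to compound 4 (0.07 log units; within the scatter)), and the new group also stays level with the 2-fluorophenyl group (a 1.6-fold lower number from compound 1 to compound 4 (0.21 log units; within the scatter)), so compound 3 alone stands apart among the four compounds. Nothing measured here explains why the 2-methoxyphenyl group differs so sharply from the other three groups.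

From the compounds shown here alone, it remains open whether that high number belongs to methoxy in particular, or whether a hydroxy, ethoxy or trifluoromethyl group on the same ring would give a similar value. Going by these compounds, it is also open how much more the ring accepts where the methyl sits, for instance an amine, a carboxylic acid or a longer chain in its place.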